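The compounds below may be only part of what the source reports. "The series", "measured", "known", "first", "only" and "open" are said of these compounds alone.

Among the measured compounds shown here, in an ADME assay on HepG2 cells (Homo sapiens) for cytotoxicity, read by MTT assay, with a stated time of 72 h (a lower number here means that less compound is tolerated, a higher number that more compound is tolerated), compound 3 `O=[N+]([O-])c1c(CS(=O)(=O)c2ccccc2)nc2c(-c3ccc(CO)cc3)cc(Cl)cn12` gives 13100 nM, the only exact number among the three measured compounds. Compound 1 `O=[N+]([O-])c1c(CS(=O)(=O)c2ccccc2)nc2c(-c3ccc(Cl)cc3)cc(Cl)cn12` reads > 3900 nM, which is a limit. Compound 2 `O=Cc1ccc(-c2cc(Cl)cn3c([N+](=O)[O-])c(CS(=O)(=O)c4ccccc4)nc23)cc1` reads > 31200 nM, which is also a limit. Compound 4 `O=[N+]([O-])c1c(CS(=O)(=O)c2ccccc2)nc2c(-c3ccc(C(F)(F)F)cc3)cc(Cl)cn12` carries trifluoromethyl in place of hydroxymethyl on an aromatic carbon, para to a large group: trifluoromethyl in place of hydroxymethyl on an aromatic carbon. For the measured compounds named here, no measured step makes this exchange. Going by the values given here, the only readable step at this place is an at least 2.3-fold lower number from compound 2 to compound 3 (0.37 log units; beyond the scatter), while the others are a step that the two limits leave unreadable from compound 1 to compound 2 and a step that the limit leaves unreadable from compound 1 to compound 3. With so little to go on, the expected change is small and within the scatter, as a 1.1-fold lower number from compound 3 to compound 4 (0.04 log units; within the scatter). Compound 4 is estimated at 12000 nM, with an expected range of 4000 nM to 32000 nM.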

Compound 4, half-maximal cytotoxic concentration: > 3900 nM
Compound 4: only a limit was reported; the forecaster's own chance of this, stated with the estimate: 50%; the middle value does not contradict the limit.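

In this assay, among the compounds shown here, compound 4 gives only a limit, and no step from compound 1, compound 2 or compound 3 to compound 4 can be read. The compounds shown leave open how trifluoromethyl compares in size of effect with chloro, formyl or hydroxymethyl.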